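Returning to an aryl amide after a difluorobenzyl limit

The compounds below may be only part of what the source reports. "The series", "measured", "known", "first", "only" and "open" are said of these compounds alone.

Compound 1 `COc1cccc(NC(=O)/C=C/c2coc3cc(OC)ccc3c2=O)c1` gives 11100 nM in a functional assay on Huh-7 cells (Homo sapiens) for inhibition, read by MTT assay, with a stated time of 48 h; on this read-out higher numbers stand for weaker inhibition and lower numbers for stronger inhibition. Compound 2 `COc1ccc2c(=O)c(/C=C/C(=O)NCc3ccc(F)cc3)coc2c1` gives 21000 nM; the step of a 1.9-fold higher number from compound 1 to compound 2 (0.28 log units; within the scatter). Compound 3 `COc1ccc2c(=O)c(/C=C/C(=O)NCc3ccc(F)cc3F)coc2c1` reaches only the assay limit of > 100000 nM, so no number is known for it (the limit of > 100000 nM in this assay, at which 1 of the 3 values shown sits). The steps of an at least 9.0-fold higher number from compound 1 to compound 3 (0.95 log units; beyond the scatter) and an at least 4.7-fold higher number from compound 2 to compound 3 (0.67 log units; beyond the scatter). Compound 4 `COc1ccc2c(=O)c(/C=C/C(=O)Nc3ccc(C)cc3)coc2c1` differs from compound 3 by 4-methylphenyl in place of 2,4-difluorobenzyl on an amide-type nitrogen. Compound 4 resembles compound 1 more than compound 3 does, and because compound 1 is at 11100 nM a return toward that level is expected, as a step of an at least 6.6-fold lower number from compound 3 to compound 4 (0.82 log units; beyond the scatter). Compound 4 is therefore estimated at 15000 nM, within 5000 nM to 60000 nM.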

Compound 4, half-maximal inhibitory concentration: > 100000 nM
Compound 4 gave a limit, no number; the forecaster's own chance of this, stated with the estimate: 15%; middle value at least 6.6-fold (0.82 log units) from the limit.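

Moving from 3-methoxyphenyl to 4-methylphenyl gives an at least 9.0-fold higher number from compound 1 to compound 4 (0.95 log units; beyond the scatter), so an aryl group on the amide-type nitrogen does not by itself keep a measurable value; what that ring carries matters. Against the 4-fluorobenzyl amide, the change gives an at least 4.7-fold higher number from compound 2 to compound 4 (0.67 log units; beyond the scatter). The step linking compound 3 and compound 4 joins two limits and cannot be read: the limit of > 100000 nM in this assay, at which 2 of the 4 values shown sit.

Still open, as far as these compounds go, is whether the methyl group or its place on the ring makes the difference. From the compounds shown here alone, a plain phenyl or a 4-methoxyphenyl on the same nitrogen would separate these two, and a ring carrying an amine or a carboxylic acid remains untested territory here.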